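The compounds below may be only part of what the source reports. "The series", "measured", "known", "first", "only" and "open" are said of these compounds alone.

Measured compounds:
Compound 1, `O=C(O)c1cc(-c2cccc(COc3ccc4c(c3)CN(C3CCCCC3)C4=O)c2)ccc1Cl`: 270 nM in an assay on HEK293 cells for positive allosteric modulation of metabotropic glutamate receptor 2 (Rattus norvegicus), read by thallium flux; a lower number here means that less compound is needed, a higher number that more compound is needed for the effect
Compound 2, `O=C(O)c1cc(-c2cccc(COc3ccc4c(c3)CN(c3ccccc3)C4=O)c2)ccc1Cl`: 260 nM in this assay
Compound 3, `CC(C)N1Cc2cc(OCc3cccc(-c4ccc(Cl)c(C(=O)O)c4)c3)ccc2C1=O`: 70 nM in this assay

Compound 3 has the lowest number of the three; the nearest is compound 2, with the step of a 3.7-fold lower number from compound 2 to compound 3 (0.57 log units; beyond the scatter), and the furthest compound 1, with the step of a 3.9-fold lower number from compound 1 to compound 3 (0.59 log units; beyond the scatter). Both steps are beyond the scatter, whereas the step of a 1.0-fold lower number from compound 1 to compound 2 (0.02 log units; within the scatter) is within it, so the two larger groups on the ring nitrogen are not told apart, while the isopropyl group gives a clearly lower number.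

Compound 4, `O=C(O)c1cc(-c2cccc(COc3ccc4c(c3)CN(C3CC3)C4=O)c2)ccc1Cl`, is the next member of the series: cyclopropyl in place of isopropyl on an amide-type nitrogen in a ring. This change keeps the same place as the measured steps and exchanges one three-carbon group for another. Among the measured compounds shown here, no measured step tests an isopropyl against a cyclopropyl group, so the two steps ending at compound 3 can only suggest that a small group here does well. The step of a 1.1-fold higher number from compound 3 to compound 4 (0.06 log units; within the scatter) is therefore expected to stay within the scatter. Compound 4 is estimated at 80 nM in this assay, within a range of 30 nM to 220 nM.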

Compound 4, half-maximal effective concentration: 220 nM
The estimate for compound 4 lay 2.8-fold (0.44 log units) below the measured number; the range from low to high includes it.
By their numbers in this assay, from the lowest: compound 3; then compounds 4, 2 and 1 (each within the scatter of the next).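

In this assay, isopropyl and cyclopropyl on an amide-type nitrogen in a ring are not interchangeable, even though both groups have the same count of carbon atoms: a 3.1-fold higher number from compound 3 to compound 4 (0.50 log units; beyond the scatter) lies beyond the scatter. Cyclopropyl is also not told apart from the two larger groups, since a 1.2-fold lower number from compound 2 to compound 4 (0.07 log units; within the scatter) and a 1.2-fold lower number from compound 1 to compound 4 (0.09 log units; within the scatter) both lie within the scatter. The earlier suggestion that a small group does well here therefore does not hold generally: among these four compounds only the isopropyl group of compound 3 stands apart, and the small cyclopropyl group of compound 4 goes against that pattern.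

Nothing shown explains the difference between these two groups. Also open, from the compounds shown here alone, is how an ethyl or tert-butyl group, a longer chain or a chain ending in an amine on this nitrogen would read.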